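Cyclohexylamino to pyrrolidin-1-yl on the benzyl-bearing core

A few compounds are considered here, and "the series" means these few. Any claim that something is new, unique, unknown or untested is made for them only; others in the source may bear on it.

Measured compounds:
compound 1 `CCCNc1nc2c(NC3CCCC3)ncnc2n1[C@@H]1O[C@H](CO)[C@@H](O)[C@H]1O`: 97 nM
compound 2 `CCCCCCNc1nc2c(SCc3ccccc3)ncnc2n1C1O[C@H](CO)[C@@H](O)[C@H]1O`: 3.7 nM
compound 3 `O=[N+]([O-])c1ccc(CSc2ncnc3c2nc(NC2CCCCC2)n3Cc2ccccc2)cc1`: 55 nM

All three were run in an assay on cell membranes for binding affinity to Equilibrative nucleoside transporter 1 (Homo sapiens); a lower number here means a stronger inhibitor, a higher number a weaker inhibitor. Compound 3 stands second highest of the three numbers. Its nearest neighbour is compound 1, whose number sits above it but within the usual scatter, so no order between compound 3 and compound 1 can be read from these two values. Compound 2 lies far below both, beyond the scatter, and is the strongest inhibitor among the three.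

Compound 4 `O=[N+]([O-])c1ccc(CSc2ncnc3c2nc(N2CCCC2)n3Cc2ccccc2)cc1` has not yet been measured. It differs from compound 3 in one place: pyrrolidin-1-yl in place of cyclohexylamino on an aromatic carbon. The group that leaves carries one hydrogen-bond donor; the entering group carries none. Among the measured compounds shown here, no pair of measured compounds shows this change, so the expected size of the step cannot be taken from the data. The step from compound 3 to compound 4 is expected to be a 2.9-fold higher number from compound 3 to compound 4 (0.46 log units; beyond the scatter), a move toward a higher number. Compound 4 is estimated at 160 nM, within a range from 50 nM to 500 nM.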

Compound 4, inhibition constant: 1520 nM
For compound 4 the middle estimate is 9.5-fold (0.98 log units) below the measured one; measured number outside the range, above it.
By their numbers in this assay, from the lowest: compound 2; then compounds 3 and 1 (each within the scatter of the next); then compound 4.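

At the aromatic carbon between two ring nitrogen atoms, this position proves highly sensitive in this assay: pyrrolidin-1-yl in place of cyclohexylamino gives a 28-fold higher number from compound 3 to compound 4 (1.44 log units; beyond the scatter) on an otherwise unchanged core. The change removes the hydrogen-bond donor of the leaving group and also goes from a six-membered ring of carbon only to a five-membered ring with 1 hetero atom, and this single pair cannot separate the two differences. No measurement on hand accounts for the size of the step.

Open, from the compounds shown here alone, is whether the donor or the ring matters more: a dimethylamino group or a piperidin-1-yl group at this place would help to separate them. Also open, going by these compounds, is whether the same sensitivity holds on the sugar-bearing cores of compound 1 and compound 2, which differ from compound 3 in more than one place.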